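Swapping an anilino for a thiophenylmethylamino group: cytotoxicity

The source may report more compounds than this note shows. Statements on the series, on what has been measured and on what is new or still open speak of the compounds shown alone.

In an ADME assay on cells (Homo sapiens) for cytotoxicity, read by polymerase chain reaction, with a stated time of 3 days (on this read-out higher numbers stand for lower toxicity in this test and lower numbers for higher toxicity in this test), the measured compounds stand as follows. Compound 1 `CCOC(=O)NCCNc1nc(C)c(-c2nc3ccccc3s2)c(N[C@@H]2C[C@H](CO)[C@@H](O)[C@H]2O)n1` gives 12000 nM. Compound 2 `Cc1nc(NCCNC(=O)NC(C)(C)C)nc(N[C@@H]2C[C@H](CO)[C@@H](O)[C@H]2O)c1-c1nc2ccccc2s1` gives > 25000 nM, which is a limit of the assay rather than a number. Compound 3 `Cc1nc(Nc2ccccc2)nc(N[C@@H]2C[C@H](CO)[C@@H](O)[C@H]2O)c1-c1nc2ccccc2s1` gives > 25000 nM, again a limit and not a number.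

Compound 3 therefore stands at the top of what this test reports, together with compound 2 (the limit of > 25000 nM in this assay, at which 2 of the 3 values shown sit). Compound 4 `Cc1nc(NCc2ccsc2)nc(N[C@@H]2C[C@H](CO)[C@@H](O)[C@H]2O)c1-c1nc2ccccc2s1` differs from compound 3 by (thiophen-3-yl)methyl in place of phenyl on a nitrogen on an aromatic ring. For the measured compounds named here, only one measured step touches that same nitrogen: an at least 2.0-fold higher number from compound 1 to compound 3 (0.31 log units; beyond the scatter), which moved into the limit. The step that the two limits leave unreadable from compound 2 to compound 3 gives no readable size. Going by the values given here, no measured step exchanges two groups on that nitrogen while staying within readable numbers, so no direction can be taken from the data.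

Compound 4 is expected to remain at or near the limit, with an estimated step of an at least 1.1-fold lower number from compound 3 to compound 4 (0.05 log units; that floor lies within the scatter). Compound 4 is estimated at 22000 nM, between 9000 nM and 50000 nM.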

Compound 4, half-maximal cytotoxic concentration: 6000 nM
Beside the measured number, compound 4's estimate is 3.7-fold (0.56 log units) above it, outside the stated range (below it).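

In this assay, this nitrogen proves sensitive to the group it carries, and anilino to ((thiophen-3-yl)methyl)amino gives an at least 4.1-fold lower number from compound 3 to compound 4 (0.61 log units; beyond the scatter). Compound 2 and compound 3 each stand at a limit of the assay, not at a number: the limit of > 25000 nM in this assay, at which 2 of the 4 values shown sit. A ring on this nitrogen therefore does not by itself keep the reading at that limit, and the open chains offer no simple contrast, with an at least 4.1-fold lower number from compound 2 to compound 4 (0.61 log units; beyond the scatter), whereas a 2.0-fold lower number from compound 1 to compound 4 (0.30 log units; within the scatter).

The compounds shown do not separate the exchange of the ring from the methyl link that comes with it, so it remains open whether a benzylamino group on this nitrogen would read like compound 3 or like compound 4. On these data alone, it is equally open whether a ((thiophen-2-yl)methyl)amino group would read like compound 4.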